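Cytotoxicity notes: compound 3 to compound 4

The source may report more compounds than this note shows. Statements on the series, on what has been measured and on what is new or still open speak of the compounds shown alone.

Measured in a functional assay on U2OS cells (Homo sapiens) for cytotoxicity, read by MTT assay, with a stated time of 48 h; a lower number here means a stronger inhibitor, a higher number a weaker inhibitor:
- compound 1 `Fc1cccc(-c2nc(Nc3ccccc3Cl)c3cc(F)ccc3n2)c1`: > 50000 nM (a limit)
- compound 2 `Oc1ccc(Nc2nc(-c3cccc(F)c3)nc3ccc(F)cc23)cc1`: > 50000 nM (a limit)
- compound 3 `Oc1ccccc1Nc1nc(-c2cccc(F)c2)nc2ccc(F)cc12`: 41400 nM

Going by the values given here, compound 3 holds the only true number in the set. The other two entries sit at the limit of > 50000 nM in this assay, at which 2 of the 3 values shown sit.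

Next is compound 4 `Nc1ccc(Nc2nc(-c3cccc(F)c3)nc3ccc(F)cc23)cc1`, with 4-aminophenyl in place of 2-hydroxyphenyl on a nitrogen on an aromatic ring.

Among the compounds with values here, two measured steps bear on this: an at least 1.2-fold lower number from compound 2 to compound 3 (0.08 log units; that floor lies within the scatter) and an at least 1.2-fold lower number from compound 1 to compound 3 (0.08 log units; that floor lies within the scatter). The third is a step that the two limits leave unreadable from compound 1 to compound 2. Compound 2, the 4-hydroxyphenyl member, reads > 50000 nM, a limit.

A small move toward a higher number is expected, not clearly beyond the scatter. The expected step is a 1.2-fold higher number from compound 3 to compound 4 (0.06 log units; within the scatter). Compound 4 is estimated at 48000 nM, with an expected range of 20000 nM to 110000 nM.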

Compound 4, half-maximal inhibitory concentration: 44200 nM
For compound 4 the middle estimate is 1.1-fold (0.04 log units) above the measured one, and the stated range covers the measured number.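

In this assay, 4-aminophenyl in place of 2-hydroxyphenyl on the nitrogen gives a 1.1-fold higher number from compound 3 to compound 4 (0.03 log units; within the scatter), so compound 4 supplies a second true number and the change leaves the two compounds within the scatter of each other. The steps from the limit entries are only floors, an at least 1.1-fold lower number from compound 2 to compound 4 (0.05 log units; that floor lies within the scatter) and an at least 1.1-fold lower number from compound 1 to compound 4 (0.05 log units; that floor lies within the scatter), and neither separates compound 4 from compound 2 or compound 1. Those two entries remain limits: the limit of > 50000 nM in this assay, at which 2 of the 4 values shown sit.

Still open, on these data alone, is whether any group on this phenyl ring moves the number beyond the scatter. A carboxylic acid or a 2-aminophenyl group would test this.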